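Lipophilicity notes on an amide-to-carbamate change

The source may report more compounds than this note shows. Statements on the series, on what has been measured and on what is new or still open speak of the compounds shown alone.

Compound 1 `Cc1cc(C(=O)NC(C)C)nn1Cc1cc(Cl)ccc1OCc1ccccc1` is the reference. In a physicochemical assay for lipophilicity, at pH 7.4 (on this read-out higher numbers stand for higher lipophilicity and lower numbers for lower lipophilicity), compound 1 gives > 3.7, a limit of the assay and not a number. Compound 2 `Cc1cc(NC(=O)C2CCCO2)nn1Cc1cc(Cl)ccc1OCc1ccccc1` in this assay gives > 3.7, also a limit. Compound 3 `Cc1cc(NC(=O)c2ccccc2)nn1Cc1cc(Cl)ccc1OCc1ccccc1` in this assay gives > 3.7, again a limit. Among the measured compounds shown here, the steps a step that the two limits leave unreadable from compound 1 to compound 2, a step that the two limits leave unreadable from compound 1 to compound 3 and a step that the two limits leave unreadable from compound 2 to compound 3 therefore have no readable size; the series so far rests on (the limit of > 3.7 in this assay, at which 3 of the 3 values shown sit).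

Compound 4 `CCOC(=O)Nc1cc(C)n(Cc2cc(Cl)ccc2OCc2ccccc2)n1` differs from compound 1 as follows: (ethoxycarbonyl)amino in place of isopropylcarbamoyl on an aromatic carbon. For the measured compounds named here, no measured step matches this change, and the three measured steps offer no size to lean on. Compound 4 is expected to stay close to the same limit, with an estimated step that the limit leaves unreadable from compound 1 to compound 4. The estimate for compound 4 in this assay is 4, within 3.5 to 4.6.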

Compound 4, distribution coefficient: > 3.7
Compound 4 was reported as a limit; the forecaster's own chance of this, stated with the estimate: 70%; the middle value lies beyond the limit too.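

Compound 4 gives > 3.7, a limit and not a number, so the steps to it from compound 1, compound 2 and compound 3 cannot be read. The compounds shown leave open how they rank in this assay, as none has a number: the limit of > 3.7 in this assay, at which 4 of the 4 values shown sit.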